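The source may report more compounds than this note shows. Statements on the series, on what has been measured and on what is new or still open speak of the compounds shown alone.

Measured so far in a functional assay for inhibition, with Homo sapiens as the target; on this read-out lower numbers stand for stronger inhibition and higher numbers for weaker inhibition:
compound 1, `CCOC(=O)/C(=C/c1cccc(OCC(=O)OC)c1)c1nc(-c2ccccc2)c(-c2ccccc2)o1`: 19700 nM
compound 2, `CCOC(=O)/C(=C\c1cccc(OCC(=O)OC)c1)c1nc(-c2ccccc2)c(-c2ccccc2)o1`: 2000 nM
compound 3, `O=C(O)COc1cccc(CC(C(=O)O)c2nc(-c3ccccc3)c(-c3ccccc3)o2)c1`: 14000 nM

Compound 3 holds the second highest of the three numbers in this assay. Its nearest neighbour is compound 1, whose number is within the scatter of that of compound 3, so no order between those two can be read. Compound 2 gives 2000 nM, a gap from compound 3 that lies beyond the scatter.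

For the measured compounds named here, the one step measured inside the set is a 9.9-fold lower number from compound 1 to compound 2 (0.99 log units; beyond the scatter); it rests on (the fact that compounds 1 and 2 differ only in the configuration as drawn), a change of configuration at the double bond alone. The next compound, compound 4, `O=C(O)COc1cccc(CC(CCCCO)c2nc(-c3ccccc3)c(-c3ccccc3)o2)c1`, differs from compound 3 otherwise: 4-hydroxybutyl in place of carboxy on a saturated chain carbon bound to an aromatic carbon and a saturated chain carbon. Going by the values given here, no measured step touches that position or exchanges a carboxy for a chain, so the step from compound 1 to compound 2 gives no direct guide to its size or direction. What remains is the number for compound 3 itself, and the expectation is that compound 4 stays near it, with a wide range to allow for an unmeasured type of change. For compound 4 the estimated value is 15000 nM, between 4000 nM and 50000 nM, which corresponds to an expected step of a 1.1-fold higher number from compound 3 to compound 4 (0.03 log units; within the scatter).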

Compound 4, half-maximal inhibitory concentration: 4680 nM
Compound 4: the middle estimate sits 3.2-fold (0.51 log units) above what was measured; the range from low to high includes it.
By their numbers in this assay, from the lowest: compound 2; then compound 4; then compounds 3 and 1 (each within the scatter of the next).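

In this assay, the position on a saturated chain carbon bound to an aromatic carbon and a saturated chain carbon now has a measured step of its own: 4-hydroxybutyl in place of carboxy gives a 3.0-fold lower number from compound 3 to compound 4 (0.48 log units; beyond the scatter), a modest shift towards stronger inhibition. The carboxy at this place is therefore not needed to hold the read-out in this pair, although one pair sets no trend for the series. The evidence at hand does not bear on this change.

Compounds 3 and 4 do not separate the loss of the carboxy from the gain of the chain or of its hydroxyl, so a plain butyl chain, a shorter 2-hydroxyethyl chain, or a 4-aminobutyl chain with an amine in place of the hydroxyl would each help to tell these apart. Also open, going by these compounds, is whether the same exchange gives a step of similar size and direction in compounds that carry an ethyl ester and a double bond in the chain, as compounds 1 and 2 do.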